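A few compounds are considered here, and "the series" means these few. Any claim that something is new, unique, unknown or untested is made for them only; others in the source may bear on it.

Measured compounds:
Compound 1 `COC(=O)c1sc2cc(-c3ccoc3)cnc2c1N`. In a functional assay on NCI-H460 cells (Homo sapiens) for inhibition, read by sulforhodamine B assay, with a stated time of 48 h (a lower number here means a stronger inhibitor of growth, a higher number a weaker inhibitor of growth), compound 1 gives > 120000 nM, which is a limit of the assay and not a number.
Compound 2 `COC(=O)c1sc2cc(-c3cnn(C)c3)cnc2c1N`. In this assay compound 2 gives > 150000 nM, again a limit.
Compound 3 `COC(=O)c1sc2cc(-c3ccc(C(F)(F)F)cc3)cnc2c1N`. In this assay compound 3 gives > 150000 nM, also a limit.

Compound 2 therefore stands nowhere in particular among the numbers shown: every value in the series is a limit, and compound 2 shares (the limit of > 150000 nM in this assay, at which 2 of the 3 values shown sit), while compound 1 sits at the limit of > 120000 nM in this assay, at which 1 of the 3 values shown sits. Within the data shown here, the only single-point step among the measured compounds, a step that the two limits leave unreadable from compound 1 to compound 2, cannot be read in size or direction, since both ends are limits.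

The change to compound 4 `COC(=O)c1sc2cc(-c3cccc(N)c3)cnc2c1N` is 3-aminophenyl in place of 1-methyl-1H-pyrazol-4-yl on an aromatic carbon. Among the measured compounds shown here, no measured step bears on this replacement beyond the unreadable one from compound 1 to compound 2, and the values of compound 3, compound 1 and compound 2 together show only that three different aromatic groups at this position all leave growth inhibition in this assay beyond the range of the assay. The step of a number no higher from compound 2 to compound 4 (the limit leaves the size open) is therefore expected to be none beyond the scatter, with compound 4 most likely returning another limit. Compound 4 is estimated at 150000 nM, within 30000 nM to 500000 nM.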

Compound 4, concentration for 50% growth inhibition: > 150000 nM
Compound 4: only a limit was reported; the forecaster's own chance of this, stated with the estimate: 80%; the middle value lies on the limit itself.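

In this assay compound 4 gives > 150000 nM, a limit and not a number. With compound 1 and compound 2 also at limits, the steps from these two compounds to compound 4 cannot be read in size or direction. The compounds shown leave open which aromatic group at this position, if any, brings growth inhibition within the range of the assay.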